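The source may hold more compounds than are shown below. What is called first, only, known or untested is meant among the compounds shown, and "the series" means these compounds.

Compound 1 `CCn1cc(-c2nc3ccc([N+](=O)[O-])cc3[nH]2)c(=O)c2cc(F)c(N3CCNCC3)cc21` gives 1600 nM in a functional assay on A2780 cells (Homo sapiens) for cytotoxicity, read by MTT assay, with a stated time of 48 h; a lower number here means a stronger inhibitor, a higher number a weaker inhibitor. Compound 3 `CCn1cc(-c2nc3ccc(N)cc3[nH]2)c(=O)c2cc(F)c(N3CCNCC3)cc21` carries one change from it, (amino in place of nitro on an aromatic carbon), and in this assay compound 3 gives 51500 nM, so that the step of a 32-fold higher number from compound 1 to compound 3 (1.51 log units; beyond the scatter) is a large weakening. Compound 2 `CCn1cc(-c2nc3ccc([N+](=O)[O-])cc3[nH]2)c(=O)c2cc(F)c(N3CCNCC3)nc21` stands on a different core; the difference between the two cores is not broken down here. In this assay compound 2 gives 12400 nM, a higher number than compound 1 and a lower one than compound 3. Compound 4 `CCn1cc(-c2nc3ccc(N)cc3[nH]2)c(=O)c2cc(F)c(N3CCNCC3)nc21` is related to compound 2 by the same change, (amino in place of nitro on an aromatic carbon). Because the step of a 32-fold higher number from compound 1 to compound 3 (1.51 log units; beyond the scatter) was so large, a step of similar size, a 9.7-fold higher number from compound 2 to compound 4 (0.99 log units; beyond the scatter), is expected from compound 2 to compound 4 in this assay, which would push compound 4 toward the top of the measurable range. Compound 4 is therefore estimated at 120000 nM, between 30000 nM and 400000 nM.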

Compound 4, half-maximal inhibitory concentration: 42300 nM
For compound 4 the middle estimate is 2.8-fold (0.45 log units) above the measured one; the range from low to high includes it.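

In this assay, amino in place of nitro on an aromatic carbon again raises the number on the other core, with a 3.4-fold higher number from compound 2 to compound 4 (0.53 log units; beyond the scatter). The change thus points the same way on both cores, but its size does not carry over, and the gap between the two steps is larger than scatter alone would give: the same change on two cores in this assay, a 32-fold higher number (1.51 log units; beyond the scatter) from compound 1 to compound 3 and a 3.4-fold higher number (0.53 log units; beyond the scatter) from compound 2 to compound 4, 9.4-fold (0.97 log units) apart, beyond the scatter of two such steps. This shows that the direction held on these two cores, but it does not show why the size differs, and two cores set no rule for the rest of the series.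

The compounds shown leave open how a nitrile, a carboxylic acid or an acetamide on that aromatic carbon would compare with nitro and amino. They also leave open how large the step would be on any further core.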